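Replacing Sec-Butyl by Cyclohexylmethyl on the Imine Nitrogen

The source may report more compounds than this note shows. Statements on the series, on what has been measured and on what is new or still open speak of the compounds shown alone.

Of the compounds shown here, two have been measured in an assay on isolated protein for inhibition of myosin-2 (Bos taurus), read by spectrophotometry, with a stated time of 24 min; on this read-out higher numbers stand for weaker inhibition and lower numbers for stronger inhibition. Compound 1 `CCC(C)/N=C(\C)c1c(O)c2ccccc2[nH]c1=O` stands at the edge of what the method resolves: in this assay compound 1 gives >= 100000 nM, which is a limit rather than a number, as the limit of >= 100000 nM in this assay, at which 1 of the 2 values shown sits, records. Compound 2 `C/C(=N\Cc1cccnc1)c1c(O)c2ccccc2oc1=O` carries a different core and a different group on the double-bonded nitrogen, and in this assay compound 2 gives 17000 nM. Within the data shown here, no single-point step connects compound 1 and compound 2, so their two values show only that compound 2 is the one of the pair that returned a measured number. Compound 3 `C/C(=N\CC1CCCCC1)c1c(O)c2ccccc2[nH]c1=O` has not yet been measured. It differs from compound 1 by cyclohexylmethyl in place of sec-butyl on a double-bonded nitrogen. With compound 1 known only as a limit, the step from compound 1 to compound 3 cannot be anchored to a measured pair; the expectation is a modest gain in this assay, while a second limit remains nearly as likely as a number. The estimate for compound 3 in this assay is 50000 nM, between 15000 nM and 200000 nM, an expected step of an at least 2.0-fold lower number from compound 1 to compound 3 (0.30 log units; that floor lies within the scatter).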

Compound 3, half-maximal inhibitory concentration: >= 100000 nM
Compound 3 was reported as a limit; the forecaster's own chance of this, stated with the estimate: 45%; at least 2.0-fold (0.30 log units) between middle value and limit.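

Among these compounds, compound 1 and compound 3 both gave only a limit in this assay and so no step between them can be read: the limit of >= 100000 nM in this assay, at which 2 of the 3 values shown sit.

The compounds shown leave open whether any group in place of sec-butyl on a double-bonded nitrogen would give the core of compound 1 a measured number in this assay.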